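Dipeptide ketone series: the step from compound 2 to compound 3

This account rests on a few compounds, and the source may have more. Where it says the series, first, only, none or still open, it means among the compounds named here.

Measured so far:
compound 1, `CC(C)[C@H](NC(=O)COc1cccc2ccccc12)C(=O)N[C@@H](CC(=O)O)C(=O)CSc1nc2ccccc2o1`, in a functional assay on Jurkat cells (Homo sapiens) for inhibition; a higher number here means a weaker inhibitor, a lower number a stronger inhibitor: > 200000 nM
compound 2, `CC(C)[C@H](NC(=O)COc1cccc2ccccc12)C(=O)N[C@@H](CC(=O)O)C(=O)COc1cc2ccccc2cn1`, in this assay: > 200000 nM

Both entries are limits of the assay and not numbers. In this assay compound 1 reaches only a limit, > 200000 nM. Compound 2 likewise reaches only a limit in this assay, > 200000 nM. Among the compounds with values here, the single measured step, a step that the two limits leave unreadable from compound 1 to compound 2, cannot be sized, due to the limit of > 200000 nM in this assay, at which 2 of the 2 values shown sit. So compound 2 stands at the upper edge of what the numbers can show, with nothing on either side of it that is readable.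

Compound 3, `CC(C)[C@H](NC(=O)COc1cccc2ccccc12)C(=O)N[C@@H](CC(=O)O)C(=O)COn1nnc2ccccc2c1=O`, differs from compound 2 by a group of 11 heavy atoms (7 carbon, 3 nitrogen, 1 oxygen; one six-membered aromatic ring of carbon only, one six-membered aromatic ring with 3 hetero atoms) in place of a group of 10 heavy atoms (9 carbon, 1 nitrogen; one six-membered aromatic ring of carbon only, one six-membered aromatic ring with 1 hetero atom), on an oxygen on a saturated carbon. Within the data shown here, no measured step speaks to this change: the one step available is unreadable, and both measured compounds sit at the same limit. The expectation for this assay therefore rests on the limits alone, with no readable direction, and a further limit is the most probable outcome. Compound 3 is expected to give about 250000 nM, with a range from 100000 nM to 1000000 nM. The step this estimate means, a step that the limit leaves unreadable from compound 2 to compound 3, is expected to stay inside the scatter.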

Compound 3, half-maximal inhibitory concentration: 137000 nM
The estimate for compound 3 lay 1.8-fold (0.26 log units) above the measured number; the range from low to high includes it.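

In this assay, within the data shown here, compound 3 gives 137000 nM, the first actual number, so this position on the oxygen on a saturated carbon now has one readable end. The readable steps are an at least 1.4-fold lower number from compound 2 to compound 3 (0.16 log units; that floor lies within the scatter) and an at least 1.4-fold lower number from compound 1 to compound 3 (0.16 log units; that floor lies within the scatter); each is only a floor with a limit at its other end, so the true size of the change in this assay may be larger or may stay within the scatter. The step from compound 1 to compound 2 cannot be read, and most of the series still sits at one edge of the assay: the limit of > 200000 nM in this assay, at which 2 of the 3 values shown sit.

The compounds shown do not separate the contributions of the ring nitrogens and the double bond outside aromatic rings in the group that enters, so it remains open which part of it, if any, goes with the number for compound 3. Also open, from the compounds shown here alone, is whether a simple phenyl group on the same oxygen would give a number in this assay or another limit.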